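Arylpiperazine series: acetyl in place of chloro

This account rests on a few compounds, and the source may have more. Where it says the series, first, only, none or still open, it means among the compounds named here.

Of the compounds shown here, two have been measured. Compound 1 `c1ccc(N2CCN(CCCCOc3ccc4c(c3)CCC4)CC2)cc1` carries an unsubstituted phenyl on the piperazine; in a functional assay on the whole organism for inhibition, with Mus musculus as the target, at a dose of 25 mg/kg by the oral route (a lower number here means less inhibition, a higher number more inhibition at the dose given (going by the name of the read-out)), compound 1 gives 50%. Compound 2 `Clc1ccc(N2CCN(CCCOc3ccc4c(c3)CCC4)CC2)cc1` carries a chlorophenyl; in this assay compound 2 gives 58%. Compound 2 stands highest of the two numbers, but its nearest neighbour, compound 1, lies only a little lower, a gap within the usual scatter, so the two cannot be ranked against each other. Going by the values given here, the two structures differ in more than one place, so no single step is drawn between them.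

Compound 3 `CC(=O)c1ccc(N2CCN(CCCOc3ccc4c(c3)CCC4)CC2)cc1` is not yet measured. It differs from compound 2 in one place: acetyl in place of chloro on an aromatic carbon. Among the compounds with values here, no step between measured compounds involves such a change, so there is nothing to size it by. The expectation for compound 3 in this assay is therefore a value near that of compound 2, with a step of a number 3 percentage points lower from compound 2 to compound 3 (within the scatter) not exceeding the scatter in either direction. Compound 3 is estimated at 55%, in the range 35% to 75%.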

Compound 3, a percentage reported as inhibition, in the whole organism at one dose (the size of the read-out at that dose, not a potency): 0%
The estimate for compound 3 lay 55 percentage points above the measured number, outside the stated range (below it).
By their numbers in this assay, from the lowest: compound 3; then compounds 1 and 2 (each within the scatter of the next).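

In this assay, acetyl in place of chloro on an aromatic carbon, para to a large group, gives a number 58 percentage points lower from compound 2 to compound 3 (beyond the scatter). Going by these compounds alone, this is the first step that can be sized, and it shows that this position is far from indifferent to the group it carries: with the rest of the structure unchanged, the exchange of chloro (1 heavy atom, 0 hydrogen-bond acceptors) for acetyl (3 heavy atoms, 1 hydrogen-bond acceptor) leaves compound 3 at 0%. The data at hand offer nothing that explains this loss.

A single step cannot show whether the loss follows from the carbonyl, from the added size of the group, or from the removal of chloro itself, and a methoxy, a nitrile or an amine at the same place would begin to separate these readings. Also open, from the compounds shown here alone, is whether the loss in this assay is specific to this position on the ring and to the chain of compound 2, or whether acetyl would have the same effect elsewhere.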